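Swapping a Pyridyl Arm for Bromine on the Shared Core

The source may report more compounds than this note shows. Statements on the series, on what has been measured and on what is new or still open speak of the compounds shown alone.

Of the compounds shown here, two have so far been measured in a physicochemical assay for solubility, using the shake flask method, in simulated intestinal fluid, measured as kinetic solubility, with a stated time of 2 h, at 25 degrees C, at pH 6.5; on this read-out lower numbers stand for lower solubility and higher numbers for higher solubility. Compound 1 `CNC(=O)c1nc(C)c2c(c1N)C(=O)N(Cc1ccccc1)C2=O` is the simpler of the two, and in this assay compound 1 gives 41000 nM. Compound 2 `Cc1noc(-c2nc(C)c3c(c2N)C(=O)N(Cc2ccc(-c4ccncc4)cc2)C3=O)n1` is larger. In this assay compound 2 returns only a limit, < 5000 nM, so no exact number is known for it. Compound 2 thus stands at the limit of < 5000 nM in this assay, at which 1 of the 2 values shown sits, well apart from compound 1 and at the low end of what the assay can report.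

Compound 3 `Cc1noc(-c2nc(C)c3c(c2N)C(=O)N(Cc2ccc(Br)cc2)C3=O)n1` differs from compound 2 in a single place: bromo in place of pyridin-4-yl on an aromatic carbon. Going by the values given here, no measured pair differs in exactly this way, so the size of the step has to be guessed rather than read off. Because compound 2 already sits at the limit < 5000 nM, compound 3 is expected to remain in the poorly soluble range, with an expected step that the limit leaves unreadable from compound 2 to compound 3 toward lower solubility, a shift within the usual scatter. The solubility of compound 3 in this assay is therefore estimated at 2500 nM, most likely between 500 nM and 8000 nM, and the assay may well again report only a limit.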

Compound 3, solubility: < 5000 nM
Compound 3 gave a limit, no number (the forecaster's own chance of this, stated with the estimate: 75%); the middle value lies beyond the limit too.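

In this assay, going by these compounds alone, compound 2 and compound 3 both return only a limit and not a number, so no step between them can be read. The compounds shown leave open how soluble compound 2 and compound 3 really are, and whether bromo in place of pyridin-4-yl on an aromatic carbon changes the read-out at all.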